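Amine exchange on the shared core: cytotoxicity notes

This account rests on a few compounds, and the source may have more. Where it says the series, first, only, none or still open, it means among the compounds named here.

- Compound 1 `CN1CCN(CC(=O)OC2CC3(N(C)C)CC(c4ccccc4)C2C(c2ccccc2)C3)CC1`: 39900 nM
- Compound 2 `CCN(CC)CC(=O)OC1CC2(N(C)C)CC(c3ccccc3)C1C(c1ccccc1)C2`: 30100 nM

In an ADME assay on L6 cells (Rattus norvegicus) for cytotoxicity, read by resazurin assay, with a stated time of 72 h (a lower number here means a stronger inhibitor, a higher number a weaker inhibitor), compound 1 gives 39900 nM, which lies within the scatter of compound 2 at 30100 nM. Within the data shown here, these are the only two measured numbers, so compound 1 has no clear rank.

Compound 3 `CN1CCN(CC(=O)OC2CC3(N4CCCC4)CC(c4ccccc4)C2C(c2ccccc2)C3)CC1` keeps the (((4-methylpiperazin-1-yl)methyl)carbonyl)oxy group of compound 1 and carries pyrrolidin-1-yl in place of dimethylamino on a saturated ring carbon.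

Among the measured compounds shown here, the only measured step is a 1.3-fold lower number from compound 1 to compound 2 (0.12 log units; within the scatter). It exchanges 4-methylpiperazin-1-yl for diethylamino on a saturated chain carbon bound to a carbonyl carbon, so it is not the exchange made in compound 3. For the measured compounds named here, no measured compound varies the dimethylamino group, and that step offers only weak, indirect guidance. A step beyond the scatter is therefore not expected in this assay, though the range has to stay wide.

The estimated step is a 1.3-fold lower number from compound 1 to compound 3 (0.12 log units; within the scatter), which is expected to remain within the scatter.

Compound 3 is expected at about 30000 nM, with an estimated range of 12000 nM to 60000 nM.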

Compound 3, half-maximal inhibitory concentration: 24600 nM
For compound 3 the middle estimate is 1.2-fold (0.09 log units) above the measured one, and the stated range covers the measured number.
By their numbers in this assay, from the lowest: compounds 3, 2 and 1 (each within the scatter of the next).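

In this assay, among these compounds, the exchange of dimethylamino for pyrrolidin-1-yl on the saturated ring carbon gives a 1.6-fold lower number from compound 1 to compound 3 (0.21 log units; within the scatter) and is the first reading at this position, which had not varied among the earlier compounds. A five-membered non-aromatic ring can therefore replace the two methyl groups of dimethylamino here without a step beyond the scatter. The amine on the chain had already given a 1.3-fold lower number from compound 1 to compound 2 (0.12 log units; within the scatter) on exchange of 4-methylpiperazin-1-yl for diethylamino and so each of the two amine sites has now been changed once, with neither step leaving the scatter. No evidence on the cause of this result is at hand.

Open, from the compounds shown here alone, is whether this ring carbon stays as flat in the readout with a larger ring amine such as piperidin-1-yl or morpholin-4-yl, or with a primary amine or a carboxylic acid in place of the tertiary amines seen so far. Also open, going by these compounds, is how pyrrolidin-1-yl on the ring carbon reads when paired with diethylamino on the chain, since the two exchanges are seen only separately on the shared core.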